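The compounds below may be only part of what the source reports. "The series", "measured", "known", "first", "only" and "open" are said of these compounds alone.

Measured in a functional assay on A549 cells (Homo sapiens) for antiproliferative activity, read by MTT assay, with a stated time of 48 h; on this read-out higher numbers stand for weaker inhibition and lower numbers for stronger inhibition:
- compound 1 `Cc1ccc(-c2cc(NC(=O)/C=C/c3ccc(Cl)cc3)n[nH]2)cc1`: 1490 nM
- compound 2 `COc1ccc(/C=C/C(=O)Nc2cc(-c3ccc(Br)cc3)[nH]n2)cc1`: 820 nM
- compound 3 `Cc1ccc(-c2cc(NC(=O)/C=C/c3ccc(F)cc3)n[nH]2)cc1`: 1250 nM

Compound 3, at 1250 nM, lies within the scatter of both compound 1 and compound 2, so the numbers shown do not separate it from either.

Compound 4 `COc1ccc(/C=C/C(=O)Nc2cc(-c3ccc(C)cc3)[nH]n2)cc1` is reached from compound 3 by methoxy in place of fluoro on an aromatic carbon, para to a large group: methoxy in place of fluoro on an aromatic carbon.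

For the measured compounds named here, one measured step bears on this change, the exchange of chloro for fluoro: a 1.2-fold lower number from compound 1 to compound 3 (0.08 log units; within the scatter). It shows little movement, but it does not involve methoxy. Compound 2 does carry methoxy and gives 820 nM, but it is not linked to compound 4 by a measured step. No step beyond the scatter is therefore expected in this assay, with a slight lean towards the value of compound 2.

The estimated step is a 1.2-fold lower number from compound 3 to compound 4 (0.08 log units; within the scatter).

Compound 4 is estimated at 1050 nM, with an expected range of 480 nM to 2300 nM.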

Compound 4, half-maximal inhibitory concentration: 1190 nM
Estimate against measurement, compound 4: 1.1-fold (0.05 log units) below; the measured number falls inside the stated range.
By their numbers in this assay, from the lowest: compounds 2, 4, 3 and 1 (each within the scatter of the next).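

In this assay, the change from 4-fluorophenyl to 4-methoxyphenyl brings an oxygen-bearing group to this position, yet the result is only a 1.1-fold lower number from compound 3 to compound 4 (0.02 log units; within the scatter). Measured against chloro at the same position, methoxy gives a 1.3-fold lower number from compound 1 to compound 4 (0.10 log units; within the scatter), so fluoro, chloro and methoxy are not separated here. A second exchange, methyl in place of bromo on an aromatic carbon, gives a 1.5-fold higher number from compound 2 to compound 4 (0.16 log units; within the scatter), and no further data bear on these results.

None of the exchanges shown has yet moved the read-out beyond the scatter, so neither place has a measured preference. On these data alone, whether an amine, a carboxylic acid or a longer alkoxy chain at the methoxy position would produce a larger step remains open.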